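The source may report more compounds than this note shows. Statements on the series, on what has been measured and on what is new or still open speak of the compounds shown alone.

Of the compounds shown here, three sharing one core have been measured. Compound 1 `C[C@H](CF)OC(=O)N1CCC(O[C@H]2CC[C@H](Oc3cnc(S(C)(=O)=O)cn3)CC2)CC1` gives 115% in a functional assay on isolated protein for agonist activity at Glucose-dependent insulinotropic receptor (Rattus norvegicus), read by HTRF and cAMP accumulation; on this read-out lower numbers stand for smaller maximal responses and higher numbers for larger maximal responses. Compound 2 `CS(=O)(=O)c1cnc(O[C@H]2CC[C@H](OC3CCN(C(=O)Oc4ccccc4)CC3)CC2)cn1` gives 104%, and compound 3 `CS(=O)(=O)c1cnc(O[C@H]2CC[C@H](OC3CCN(C(=O)C4(C(F)(F)F)CC4)CC3)CC2)cn1` gives 140%. Compound 3 therefore stands highest of the three: compound 1 is nearest, and compound 2 furthest below it.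

Compound 4 `CC(C)c1noc(CN2CCC(O[C@H]3CC[C@H](Oc4cnc(S(C)(=O)=O)cn4)CC3)CC2)n1` differs from compound 3 in one place: (3-isopropyl-1,2,4-oxadiazol-5-yl)methyl in place of (1-(trifluoromethyl)cyclopropyl)carbonyl on an amine nitrogen in a ring. Within the data shown here, no measured step changes this same group in this way. The steps that come closest both alter the group on the carbonyl carbon: a number 25 percentage points higher from compound 1 to compound 3 (beyond the scatter) and a number 36 percentage points higher from compound 2 to compound 3 (beyond the scatter). They show that what sits on this amine nitrogen in a ring can move the maximal response by a modest to large amount, while the smaller change a number 11 percentage points lower from compound 1 to compound 2 (beyond the scatter) moved it less. The change to compound 4 removes the carbonyl altogether and brings in an aromatic ring, so a step beyond the scatter is expected, with the direction uncertain; a fall back toward the level of compound 1 and compound 2 is taken as the more likely outcome.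

For compound 4 the expected step is a number 30 percentage points lower from compound 3 to compound 4 (beyond the scatter). Compound 4 is thus estimated at 110%, with a range from 80% to 145%.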

Compound 4, largest response reached (Emax), in percent of the reference or control that the assay uses: 115%
The estimate for compound 4 lay 5 percentage points below the measured number; measured number inside the range.
By their numbers in this assay, from the lowest: compound 2; then compounds 1 and 4 (each within the scatter of the next); then compound 3.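

In this assay the amine nitrogen in a ring does not need a carbonyl to reach a high maximal response, since (3-isopropyl-1,2,4-oxadiazol-5-yl)methyl carries none. Placed against the carbonyl-linked groups, this new group gives a number 25 percentage points lower from compound 3 to compound 4 (beyond the scatter) and a number 11 percentage points higher from compound 2 to compound 4 (beyond the scatter) and so falls inside the range those groups span. Against the 1-(fluoromethyl)ethyl carbamate it shows no change at the digits printed from compound 1 to compound 4 (within the scatter) even though the two groups share no ring, so quite different groups can give a matching maximal response at this position.

On these data alone, it remains open whether the oxadiazole ring or its isopropyl group matters more for this response, and what a plain benzyl group or a methanesulfonyl group on the same nitrogen would give. Nothing measured here explains why these groups differ.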